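The compounds below may be only part of what the source reports. "The series", "measured", "known", "first", "only" and "open" are said of these compounds alone.

Measured so far in this series:

compound 1, `O=C([C@@H]1C[C@H]1c1ccccc1)N(CCNCC1CCCC1)c1ccc(-c2ccccc2)cc1` — 2.5 nM
compound 2, `CC[C@H](C)[C@H](N)CN(C(=O)[C@@H]1C[C@H]1c1ccccc1F)c1ccc(-c2ccccc2)cc1` — 650 nM

Both compounds were run in a functional assay for agonist activity at G protein-coupled receptor 88 (Homo sapiens), read by HTRF and cAMP accumulation; on this read-out lower numbers stand for an effect already at smaller amounts and higher numbers for an effect only at larger amounts of compound. Compound 1 gives 2.5 nM. Compound 2 gives 650 nM, the higher of the two numbers, and the gap to compound 1 lies well beyond the scatter of the assay. The two structures differ in more than one place, so no single step can be read from this pair; only the two values themselves can be compared.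

Compound 3, `CC[C@H](C)[C@H](N)CN(C(=O)[C@@H]1C[C@H]1c1nc(C)cs1)c1ccc(-c2ccccc2)cc1`, has not yet been measured. It differs from compound 2 in one place: 4-methyl-1,3-thiazol-2-yl in place of 2-fluorophenyl on a saturated ring carbon. Among the measured compounds shown here, no measured pair in the set carries the same change, so the size of this step has no direct precedent here. The expected step is a 1.5-fold higher number from compound 2 to compound 3 (0.19 log units; within the scatter), most likely toward a higher number, while a step in either direction that stays within the scatter would not be surprising. On that basis compound 3 is expected to give 1000 nM, with a range from 250 nM to 4000 nM.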

Compound 3, half-maximal effective concentration: 730 nM
Compound 3: middle estimate off by 1.4-fold (0.14 log units), on the high side; the range from low to high includes it.
By their numbers in this assay, from the lowest: compound 1; then compounds 2 and 3 (each within the scatter of the next).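

Among the compounds shown here, exchanging 2-fluorophenyl for 4-methyl-1,3-thiazol-2-yl on a saturated ring carbon of the three-membered ring gives, in this assay, a 1.1-fold higher number from compound 2 to compound 3 (0.05 log units; within the scatter); this is the first reading of a change in one place. With the rest of compound 2 held constant, this place accepts a five-membered aromatic ring with 2 hetero atoms and 2 hydrogen-bond acceptors in place of a six-membered aromatic ring of carbon only with 0 hydrogen-bond acceptors, and the read-out does not separate the two groups. No measured property of either group bears on this result, so the match in values stays without an explanation.

From the compounds shown here alone, the gap between compound 1 and the other two compounds cannot be read as a single step, so it remains open whether the 4-methyl-1,3-thiazol-2-yl group would read the same alongside the side chain of compound 1. Also open, going by these compounds, is how this ring carbon responds to groups of a different kind, such as a carboxylic acid, an amine or a longer alkyl chain, since both groups seen here are aromatic rings.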